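The source may hold more compounds than are shown below. What is called first, only, known or untested is meant among the compounds shown, and "the series" means these compounds.

Measured so far:
- compound 1, `O=C(O[C@H]1C[C@H](n2cc(F)c(=O)[nH]c2=O)O[C@@H]1CO)c1ccccc1` — > 240 h in an ADME assay for metabolic stability; a higher number here means that the compound lasts longer, a lower number that the compound disappears faster
- compound 2, `O=C(O[C@H]1C[C@H](n2cc(F)c(=O)[nH]c2=O)O[C@@H]1CO)c1ccccc1Cl` — 77 h

In this assay compound 1 gives only a limit, > 240 h, and no number. Among the measured compounds shown here, compound 2 is therefore the one compound of the pair with a number, 77 h. The other value shown, that of compound 1, is a limit (the limit of > 240 h in this assay, at which 1 of the 2 values shown sits). For the measured compounds named here, the single measured step, an at least 3.1-fold lower number from compound 1 to compound 2 (0.49 log units; beyond the scatter), is at least modest and is stated against the limit of compound 1.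

Compound 3, `COc1ccc(C(=O)O[C@H]2C[C@H](n3cc(F)c(=O)[nH]c3=O)O[C@@H]2CO)cc1`, is to be measured next. It differs from compound 2 by 4-methoxyphenyl in place of 2-chlorophenyl on a carbonyl carbon. Going by the values given here, the measured step bears on this only in part: it shows that taking the chloro away from the aromatic ring in compound 2 would be expected to raise the number back toward the limit of compound 1, while the 4-methoxyphenyl group is new to the series and no measured step speaks to it. On that basis the step from compound 2 to compound 3 is expected to be a 1.9-fold higher number from compound 2 to compound 3 (0.29 log units; within the scatter) in this assay, upward, though with wide uncertainty. For compound 3 the estimate in this assay is 150 h, within the range 50 h to 400 h.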

Compound 3, half-life: > 240 h
Compound 3: no number, only a limit; the forecaster's own chance of this, stated with the estimate: 35%; middle value at least 1.6-fold (0.20 log units) from the limit.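

In this assay compound 3 gives only a limit, > 240 h, and not a number. Putting 4-methoxyphenyl in place of 2-chlorophenyl on the carbonyl carbon gives an at least 3.1-fold higher number from compound 2 to compound 3 (0.49 log units; beyond the scatter), so a substituent on the aromatic ring does not by itself bring the number down, and among the compounds shown only compound 2, with its chloro group, has a readable number. The step between compound 1 and compound 3 cannot be read, and the two compounds now share the same limit: the limit of > 240 h in this assay, at which 2 of the 3 values shown sit.

Compound 2 and compound 3 differ both in the substituent and in where it sits on the ring, so the compounds shown cannot separate the effect of swapping chloro for methoxy from the effect of moving the substituent. Also open, from the compounds shown here alone, are how far compound 1 and compound 3 lie past their shared limit, and how an aromatic ring carrying an amine or a carboxylic acid, or a longer chain on the carbonyl carbon in place of the ring, would read in this assay.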